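The compounds below may be only part of what the source reports. "The series", "measured", "known", "first", "only" and "open" are said of these compounds alone.

In an assay on isolated protein for inhibition of glucose-6-phosphatase catalytic subunit 1 (Homo sapiens), read by inositol phosphate accumulation, with a stated time of 30 min, tested at 100 uM (on this read-out lower numbers stand for less inhibition and higher numbers for more inhibition at the one concentration tested (going by the name of the read-out)), compound 3 `CC1(C)CC(=O)C2=C(C1)NC(c1ccccc1)=CC2c1ccc(F)cc1` gives 7.38%, the only figure reported among the three measured compounds. Compound 1 `CCOC(=O)C1=CC(c2ccccc2)C2=C(CC(C)(C)CC2=O)N1` is recorded in this assay as "not active" (no number reported), and compound 2 `CC1(C)CC(=O)C2=C(C1)NC(c1ccccc1)=CC2c1ccc([N+](=O)[O-])cc1` is recorded in this assay as "not active" (no number reported), so neither carries a number that can be set against compound 3. On the numbers shown, compound 3 therefore stands alone, with a small read-out. Compound 4 `CCOC(=O)C1=CC(c2ccc(F)cc2)C2=C(CC(C)(C)CC2=O)N1` has not been measured in this assay. It differs from compound 3 by ethoxycarbonyl in place of phenyl on a double-bonded ring carbon. Among the compounds with values here, compound 1 already carries the same ethoxycarbonyl group and is reported without a number, so no measured step exists to guide the expectation, and the small read-out of compound 3 leaves little room for a fall. The step is expected to stay within the usual scatter, with no direction beyond it. Compound 4 is expected to give 5% in this assay, between -5% and 15%. That amounts to an expected step of a number 2.4 percentage points lower from compound 3 to compound 4 (within the scatter) in this assay.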

Compound 4, a percentage reported as inhibition, at one concentration (the size of the read-out at that concentration, not a potency): "not active" (no number reported)
The entry for compound 4 holds no number; there is nothing to compare the estimate with.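

Compound 4, like compound 1, is recorded without a number in this assay, so no step can be read between compound 3 and compound 4. The compounds shown leave open how ethoxycarbonyl in place of phenyl alters the read-out, and no available evidence bears on this result.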